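The source may report more compounds than this note shows. Statements on the series, on what has been measured and on what is new or still open speak of the compounds shown alone.

Compounds measured so far in a functional assay on RAW264.7 cells (Mus musculus), read by fluorescence; a lower number here means a stronger inhibitor, a higher number a weaker inhibitor:
- compound 1 `CCOC(=O)C1=CCCCC1S(=O)(=O)Cc1ccc(Cl)cc1F` gives 104 nM
- compound 2 `CCOC(=O)C1=CCCCC1S(=O)(=O)Cc1cccc(Cl)c1` gives 14 nM
- compound 3 `CC(C)OC(=O)C1=CCCCC1S(=O)(=O)Cc1ccc(F)cc1Cl` gives 100 nM

Among these three numbers compound 3 stands second highest. Compound 1 lies within the usual scatter of it, so the two cannot be ordered; compound 2 gives the lowest number, and its gap to compound 3 is beyond the scatter. Compound 4 `CCC(=O)C1=CCCCC1S(=O)(=O)Cc1ccc(F)cc1Cl` differs from compound 3 in one place: ethyl in place of isopropoxy on a carbonyl carbon. Among the measured compounds shown here, no measured pair shows this change, so nothing in the data fixes its size. The expectation is a modest step toward a weaker inhibitor in this assay, of a size that may not clear the scatter, written as a 1.5-fold higher number from compound 3 to compound 4 (0.18 log units; within the scatter). Compound 4 is therefore estimated at 150 nM, in a range from 50 nM to 500 nM.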

Compound 4, half-maximal inhibitory concentration: 64 nM
Beside the measured number, compound 4's estimate is 2.3-fold (0.37 log units) above it; measured number inside the range.
By their numbers in this assay, from the lowest: compound 2; then compounds 4, 3 and 1 (each within the scatter of the next).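

In this assay, the first pair differing in one place gives a 1.6-fold lower number from compound 3 to compound 4 (0.19 log units; within the scatter), with ethyl in place of isopropoxy on a carbonyl carbon. At this position, then, isopropoxycarbonyl can give way to propanoyl, with the loss of the oxygen and the smaller group, without a step that clears the scatter. Nothing available accounts for this result. From the compounds shown here alone, whether a carboxylic acid, an amide or a longer chain on this carbonyl carbon would stay in the same range remains open. So does whether the same change would give a similar step with the halogens of compound 1 or compound 2.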